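Aryl variation on the shared core: toward compound 3

This account rests on a few compounds, and the source may have more. Where it says the series, first, only, none or still open, it means among the compounds named here.

Compound 1 `Cc1ccccc1-c1cc(-c2ccc(Cl)o2)cc(-c2ccsc2)n1` and compound 2 `Cc1ccc(-c2cc(-c3ccc(Cl)o3)cc(-c3ccsc3)n2)cc1` share one core and differ only in the methylphenyl group on an aromatic carbon. In a functional assay on HeLa cells (Homo sapiens) for cytotoxicity, in the presence of a further agent that is not named here (a lower number here means a stronger inhibitor, a higher number a weaker inhibitor), compound 1 gives 9770 nM, and compound 2 gives 16200 nM. The step of a 1.7-fold higher number from compound 1 to compound 2 (0.22 log units; within the scatter) stays within the scatter, so the two numbers cannot be ordered against each other. Among the compounds with values here, compound 2 thus stands at the higher of the two numbers measured so far, with compound 1 as its only neighbour and no separation between them beyond the scatter.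

Compound 3 `Clc1ccc(-c2cc(-c3ccsc3)nc(-c3ccccn3)c2)o1` takes the next step from compound 2: pyridin-2-yl in place of 4-methylphenyl on an aromatic carbon. Within the data shown here, no measured step exchanges a carbon-only six-membered aromatic ring for one with a ring nitrogen, so the only bearing comes from the aryl variation from compound 1 to compound 2, which was within the scatter. On that basis a step of no more than the scatter is expected in this assay, with no preferred direction, and with a wide range to cover the unknown effect of the new ring. For compound 3 the estimate is 14000 nM, between 4000 nM and 50000 nM, which is a step of a 1.2-fold lower number from compound 2 to compound 3 (0.06 log units; within the scatter) that is expected.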

Compound 3, half-maximal inhibitory concentration: 22500 nM
The estimate for compound 3 lay 1.6-fold (0.21 log units) below the measured number, within the range that was stated.
By their numbers in this assay, from the lowest: compounds 1, 2 and 3 (each within the scatter of the next, the first and the last beyond it).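

In this assay, within the data shown here, pyridin-2-yl on the aromatic carbon next to the ring nitrogen can now be read against both methylphenyl groups: a 1.4-fold higher number from compound 2 to compound 3 (0.14 log units; within the scatter) gives no separation from 4-methylphenyl, whereas a 2.3-fold higher number from compound 1 to compound 3 (0.36 log units; beyond the scatter) is the only step that clears the scatter, and only modestly. Compound 2 lies within the scatter of both compound 1 and compound 3, so only the two ends of the series separate, and that separation cannot be assigned to the ring nitrogen alone, since the step from 2-methylphenyl to pyridin-2-yl also removes the methyl group. No accompanying measurement bears on this result, and its origin stays unassigned.

Open, going by these compounds, is whether a plain phenyl group would read with the methylphenyl compounds or with compound 3, which would separate the ring nitrogen from the methyl group. Also open, on these data alone, is how this assay would respond to a larger change at this position, such as an aryl ring carrying an amine or a carboxylic acid.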